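This account rests on a few compounds, and the source may have more. Where it says the series, first, only, none or still open, it means among the compounds named here.

Series notes. Compound 3 `COc1ncc(-c2cc3c(N4CCC(OC)CC4)ncnc3s2)cc1NS(=O)(=O)c1ccc(F)cc1F` shares its core with compound 1 `COc1ncc(-c2cc3c(N4C[C@@H](C)O[C@@H](C)C4)ncnc3s2)cc1NS(=O)(=O)c1ccc(F)cc1F` and compound 2 `COc1ncc(-c2cc3c(N4CCCCC4)ncnc3s2)cc1NS(=O)(=O)c1ccc(F)cc1F`, the three differing only in the saturated amine on that core. In a functional assay on HGC-27 cells (Homo sapiens) for antiproliferative activity, read by MTT assay, with stated times of 72 h and 4 h (on this read-out higher numbers stand for weaker inhibition and lower numbers for stronger inhibition), compound 3 gives 280 nM, the lowest of the three numbers; compound 1 gives 560 nM and compound 2 gives 1200 nM. The step of a 2.0-fold lower number from compound 1 to compound 3 (0.30 log units; within the scatter) lies within the scatter, so compound 3 and compound 1 cannot be separated, whereas a 4.3-fold lower number from compound 2 to compound 3 (0.63 log units; beyond the scatter) and a 2.1-fold higher number from compound 1 to compound 2 (0.33 log units; beyond the scatter) are beyond it.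

Compound 4 `COc1ncc(-c2cc3c(N4CC5CCCC5C4)ncnc3s2)cc1NS(=O)(=O)c1ccc(F)cc1F` differs from compound 3 by a group of 8 heavy atoms (7 carbon, 1 nitrogen; one five-membered non-aromatic ring of carbon only, one five-membered non-aromatic ring with 1 hetero atom) in place of a group of 8 heavy atoms (6 carbon, 1 nitrogen, 1 oxygen; one six-membered non-aromatic ring with 1 hetero atom), on an aromatic carbon. The change removes the methoxy whose entry produced a 4.3-fold lower number from compound 2 to compound 3 (0.63 log units; beyond the scatter), and the entering group, like the piperidin-1-yl of compound 2, carries no methoxy. Within the data shown here, that step is the one that bears on it; for the change from a six-membered to a fused pair of five-membered rings no measured step exists. A number nearer that of compound 2 is therefore expected, the expected step being a 3.2-fold higher number from compound 3 to compound 4 (0.51 log units; beyond the scatter). For compound 4 the estimate is 900 nM, with a range from 400 nM to 2500 nM.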

Compound 4, half-maximal inhibitory concentration: 1900 nM
Compound 4: the middle estimate sits 2.1-fold (0.32 log units) below what was measured; measured number inside the range.
By their numbers in this assay, from the lowest: compounds 3 and 1 (each within the scatter of the next); then compounds 2 and 4 (each within the scatter of the next).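

In this assay the fused pair of five-membered rings cannot be separated from the piperidin-1-yl of compound 2, with a 1.6-fold higher number from compound 2 to compound 4 (0.20 log units; within the scatter), so this change of ring shape at the position gives no measurable gain or loss. The same group stands apart from both oxygen-bearing amines, with a 6.8-fold higher number from compound 3 to compound 4 (0.83 log units; beyond the scatter) and a 3.4-fold higher number from compound 1 to compound 4 (0.53 log units; beyond the scatter), so among these four compounds the two lower numbers belong to amines carrying oxygen and the two higher to amines without it, and no compound goes against this. Nothing measured here accounts for that split.

Still open, going by these compounds, is whether the split holds for other oxygen-bearing amines, such as morpholin-4-yl or 4-hydroxypiperidin-1-yl. Equally open, on these data alone, is how a ring nitrogen-bearing group such as piperazin-1-yl would read at this position.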